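Shrinking the side group on compound 3

The source may hold more compounds than are shown below. What is called first, only, known or untested is meant among the compounds shown, and "the series" means these compounds.

Compound 1 `CC/N=C(/N)Nc1nc(-c2ccc(OC)cc2)c(-c2ccc(OC)cc2)s1` gives > 100 nM, which is a limit, not a number.
Compound 2 `COc1ccc(-c2nc(CN(C)C)sc2-c2ccc(OC)cc2)cc1` gives 96 nM.
Compound 3 `COc1ccc(-c2nc(CNC(=O)NC(C)C)sc2-c2ccc(OC)cc2)cc1` gives 42 nM.

In a functional assay with Oryctolagus cuniculus as the target (a higher number here means a weaker inhibitor, a lower number a stronger inhibitor), compound 3 stands lowest, with 42 nM, and a lower number means a stronger inhibitor. Compound 4 `COc1ccc(-c2nc(C(=O)N(C)C)sc2-c2ccc(OC)cc2)cc1` carries dimethylcarbamoyl in place of ((isopropylcarbamoyl)amino)methyl on an aromatic carbon. The closest measured change to this group is a 2.3-fold lower number from compound 2 to compound 3 (0.36 log units; beyond the scatter), a modest step. The step of an at least 2.3-fold lower number from compound 1 to compound 3 (0.37 log units; beyond the scatter) is also at least modest, whereas an at least 1.0-fold lower number from compound 1 to compound 2 (0.01 log units; that floor lies within the scatter) stays within the scatter. Losing the group that gave compound 3 its edge should therefore give back about that much, so a modest move to a higher number is expected: a 1.9-fold higher number from compound 3 to compound 4 (0.28 log units; within the scatter). The estimate for compound 4 is 80 nM, in a range from 25 nM to 250 nM.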

Compound 4, half-maximal inhibitory concentration: < 100 nM
Compound 4: no number, only a limit; the forecaster's own chance of this, stated with the estimate: 30%; the middle value lies beyond the limit too.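

For compound 4, < 100 nM is a limit of the assay, not a number. It shows only that dimethylcarbamoyl, with 0 hydrogen-bond donors, can sit on this aromatic carbon in place of ((isopropylcarbamoyl)amino)methyl and still leave the compound on the stronger side of that limit. The data give a number no higher from compound 1 to compound 4 (the limit leaves the size open). The steps to compound 4 from compound 2 and compound 3 cannot be read in size: the limit of < 100 nM in this assay, at which 1 of the 4 values shown sits.

Where compound 4 truly stands against compound 3 remains open. So does the effect of a carboxylic acid or a primary amine on this aromatic carbon.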